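Chain extension and halogen swap at the amide end

The source may report more compounds than this note shows. Statements on the series, on what has been measured and on what is new or still open speak of the compounds shown alone.

Measured compounds:
compound 1 `CC(C(=O)NCc1ccc(Br)cc1)c1ccc(NS(C)(=O)=O)c(F)c1` — 250 nM
compound 2 `CC(C(=O)NCc1ccc(C2C=CCC2)cc1)c1ccc(NS(C)(=O)=O)c(F)c1` — 15 nM
compound 3 `CC(C(=O)NCc1ccc(C2CCCC2)cc1)c1ccc(NS(C)(=O)=O)c(F)c1` — 20.8 nM

The three measured compounds share one core and differ only in the group attached to the arm on the amide nitrogen. In a functional assay on CHO cells for antagonist activity at transient receptor potential cation channel subfamily V member 1 (Rattus norvegicus) (on this read-out lower numbers stand for stronger inhibition and higher numbers for weaker inhibition), compound 1 gives 250 nM, the highest number of the three. Compound 2 gives 15 nM and compound 3 gives 20.8 nM. The steps are large: a 17-fold lower number from compound 1 to compound 2 (1.22 log units; beyond the scatter) and a 12-fold lower number from compound 1 to compound 3 (1.08 log units; beyond the scatter), whereas a 1.4-fold higher number from compound 2 to compound 3 (0.14 log units; within the scatter).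

Compound 4 `CC(C(=O)NCCCc1ccc(Cl)cc1)c1ccc(NS(C)(=O)=O)c(F)c1` is the unmeasured one. Relative to compound 1 the change is 2-(4-chlorophenyl)ethyl in place of 4-bromophenyl on a saturated chain carbon bound to an amide-type nitrogen. Within the data shown here, none of the measured steps swaps one halogen for another or lengthens the chain between the amide nitrogen and the ring; they only show that what sits at this end of the molecule can shift the number strongly. On these data alone, for a halogen-to-halogen exchange alone little change would be expected, and the longer chain is untested, so the expected step is small with a wide uncertainty in either direction. For compound 4 the estimate in this assay is 350 nM, with a range from 100 nM to 1500 nM, corresponding to an expected step of a 1.4-fold higher number from compound 1 to compound 4 (0.15 log units; within the scatter).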

Compound 4, inhibition constant: 135 nM
Estimate against measurement, compound 4: 2.6-fold (0.41 log units) above; the range from low to high includes it.
By their numbers in this assay, from the lowest: compounds 2 and 3 (each within the scatter of the next); then compounds 4 and 1 (each within the scatter of the next).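

In this assay, putting 2-(4-chlorophenyl)ethyl in place of 4-bromophenyl gives a 1.9-fold lower number from compound 1 to compound 4 (0.27 log units; within the scatter), so this single swap, which brings in both a longer arm and a different halogen, produces no readable shift. The earlier compounds shown here showed only that this end of the molecule can move the number strongly, as with a 17-fold lower number from compound 1 to compound 2 (1.22 log units; beyond the scatter), whereas compound 4 shows that a substantial rebuilding of the same end can leave it within the usual scatter of repeated measurements. Nothing available explains why one replacement has a large effect here and the other does not.

Compound 4 combines two changes, and opposing effects of chlorine in place of bromine and of the longer arm would look the same as two changes that each do very little, so 4-chlorophenyl and 2-(4-bromophenyl)ethyl would be needed to tell these cases apart. Also open, on these data alone, is whether the large steps seen with cyclopentyl and cyclopent-2-en-1-yl carry over to a longer arm, as in 2-(4-cyclopentylphenyl)ethyl, and how a still longer chain such as 3-(4-chlorophenyl)propyl would read.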